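Oxadiazole tail variation in a benzenesulfonamide series

This account rests on a few compounds, and the source may have more. Where it says the series, first, only, none or still open, it means among the compounds named here.

Measured so far:
compound 1 `CCOC(=O)c1cn(Cc2nnc(-c3cc(S(N)(=O)=O)c(SCc4ccccc4)cc3Cl)o2)nn1`: 122000 nM
compound 2 `CC(C)(O)c1cn(Cc2nnc(-c3cc(S(N)(=O)=O)c(SCc4ccccc4)cc3Cl)o2)nn1`: 68000 nM
compound 3 `NS(=O)(=O)c1cc(-c2nnc(CNS(=O)(=O)c3ccc(Cl)cc3)o2)c(Cl)cc1SCc1ccccc1`: 24000 nM

In a functional assay on HeLa cells (Homo sapiens) for cytotoxicity, read by MTT assay, with a stated time of 72 h (on this read-out lower numbers stand for stronger inhibition and higher numbers for weaker inhibition), compound 3 gives the lowest of the three numbers. Its nearest neighbour is compound 2, with a 2.8-fold lower number from compound 2 to compound 3 (0.45 log units; beyond the scatter); compound 1 lies furthest, with a 5.1-fold lower number from compound 1 to compound 3 (0.71 log units; beyond the scatter). Between compound 1 and compound 2 the step is a 1.8-fold lower number from compound 1 to compound 2 (0.25 log units; within the scatter).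

Compound 4 `NS(=O)(=O)c1cc(-c2nnc(/C=C/c3c(Cl)cccc3Cl)o2)c(Cl)cc1SCc1ccccc1` is not yet measured. It changes compound 3 at the tail on the five-membered ring: 2-(2,6-dichlorophenyl)ethenyl in place of (((4-chlorophenyl)sulfonyl)amino)methyl on an aromatic carbon. For the measured compounds named here, no measured step replaces this tail with a group bound directly to the ring carbon; the two steps that reach compound 3 swap only the group on the saturated chain carbon, and both were modest. The nearest guidance is therefore that tail changes in this region have so far moved this assay by modest amounts, with compound 3 at the low end. Given that, a step beyond the scatter in either direction cannot be ruled out, but no strong move is expected.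

Compound 4 is therefore estimated at 18000 nM, in a range of 6000 nM to 55000 nM, corresponding to an expected step of a 1.3-fold lower number from compound 3 to compound 4 (0.12 log units; within the scatter).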

Compound 4, half-maximal inhibitory concentration: 12000 nM
Beside the measured number, compound 4's estimate is 1.5-fold (0.18 log units) above it; low and high end bracket the measured number.
By their numbers in this assay, from the lowest: compounds 4 and 3 (each within the scatter of the next); then compounds 2 and 1 (each within the scatter of the next).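

In this assay, the tail on the five-membered ring tolerates a complete change of type: 2-(2,6-dichlorophenyl)ethenyl, with no hydrogen-bond donors or acceptors, replaces (((4-chlorophenyl)sulfonyl)amino)methyl with no step beyond the scatter (a 2.0-fold lower number from compound 3 to compound 4 (0.30 log units; within the scatter)), so the sulfonyl amino link is not required to hold this level among the four compounds. Set against the tails that carry a triazole, the same group gives a clear separation (a 5.7-fold lower number from compound 2 to compound 4 (0.75 log units; beyond the scatter)) and the only large step in the set (a 10-fold lower number from compound 1 to compound 4 (1.01 log units; beyond the scatter)), which places compound 3 and compound 4 apart from compound 1 and compound 2, with no compound of the four going against that split. Nothing measured here explains why the triazole-bearing tails differ from the other two.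

The ethenyl link and the 2,6-dichlorophenyl ring are not separated by these compounds, so a saturated ethyl link, an unsubstituted phenyl or a phenyl bearing a carboxylic acid would be needed to tell which part carries the step. Going by these compounds, the benzylthio group and the ring chlorine of the shared core stay constant throughout, so their contribution remains open, for instance on replacing benzylthio with a simple amine.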